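The source may report more compounds than this note shows. Statements on the series, on what has been measured and on what is new or still open speak of the compounds shown alone.

Compound 1, `OC[C@H]1O[C@@H](n2cc(F)c3c(-c4ccco4)ncnc32)[C@H](O)[C@@H]1O`, is the reference point of this set. In an ADME assay on MRC5 cells (Homo sapiens) for cytotoxicity, read by MTT assay, with a stated time of 72 h (a higher number here means that more compound is tolerated, a lower number that less compound is tolerated), compound 1 gives 29000 nM. Compound 2, `OC[C@H]1O[C@@H](n2cc(F)c3c(-c4ccoc4)ncnc32)[C@H](O)[C@@H]1O`, carries one change against it, (furan-3-yl in place of furan-2-yl on an aromatic carbon), and in this assay compound 2 gives 15400 nM. The resulting step, a 1.9-fold lower number from compound 1 to compound 2 (0.27 log units; within the scatter), is small enough to fall within the scatter of repeated measurements, so the two values cannot be ordered with confidence.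

Compound 3, `CCCCCCCCCCCCCCCCCCOP(=O)(O)OC[C@H]1O[C@@H](n2ccc3c(-c4ccco4)ncnc32)[C@H](O)[C@@H]1O`, belongs to a second core. How the core of compound 3 differs from that of compound 1 is not broken down here. In this assay compound 3 gives 45300 nM, the highest of the three numbers, though its gap to compound 1 lies within the scatter while its gap to compound 2 lies beyond it.

Compound 4, `CCCCCCCCCCCCCCCCCCOP(=O)(O)OC[C@H]1O[C@@H](n2ccc3c(-c4ccoc4)ncnc32)[C@H](O)[C@@H]1O`, stands to compound 3 as compound 2 stands to compound 1: the change is furan-3-yl in place of furan-2-yl on an aromatic carbon. The surroundings of the exchanged group are the same in both pairs, so it is the same change. Going by the values given here, the one measured instance of this change, a 1.9-fold lower number from compound 1 to compound 2 (0.27 log units; within the scatter), stayed within the scatter. On that basis the step from compound 3 to compound 4 is expected to be of similar size, a 1.7-fold lower number from compound 3 to compound 4 (0.22 log units; within the scatter). Compound 4 is therefore estimated at 27000 nM in this assay, with a range from 12000 nM to 60000 nM.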

Compound 4, half-maximal cytotoxic concentration: > 50000 nM
Compound 4 ended at the assay's limit (the forecaster's own chance of this, stated with the estimate: 10%); middle value at least 1.8-fold (0.26 log units) away from the limit.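

In this assay compound 4 gave > 50000 nM, which is a limit of the assay and not a number. The exchange of furan-2-yl for furan-3-yl on the second core therefore gave an at least 1.1-fold higher number from compound 3 to compound 4 (0.04 log units; that floor lies within the scatter), a floor and not a full size, and set beside the same exchange on the other core, it cannot be said whether the two steps agree: the same change on two cores in this assay, a 1.9-fold lower number (0.27 log units; within the scatter) from compound 1 to compound 2 and an at least 1.1-fold higher number (0.04 log units; that floor lies within the scatter) from compound 3 to compound 4; the limit leaves it open whether they differ. As far as these compounds go, the result neither shows that the change carries from one core to the other nor shows that it fails to, since the true size of the second step stays unknown and two pairs give no basis for a rule.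

The compounds shown leave open how a thienyl or phenyl group in the place of either furan would read in this assay, on either core. They also leave open whether a shorter chain on the phosphate would give the furan-3-yl compound a value that can be read as a number, and so allow the two steps to be compared in full.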